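A few compounds are considered here, and "the series" means these few. Any claim that something is new, unique, unknown or untested is made for them only; others in the source may bear on it.

Three compounds share one core. Compound 1 `CNC(=O)C#Cc1ccc(NC(=O)Nc2ccc(Cl)c(C(F)(F)F)c2)cc1` carries a 2-(methylcarbamoyl)ethynyl group, and in a functional assay on HT-29 cells (Homo sapiens) for inhibition, read by MTT assay, with a stated time of 120 h (a higher number here means a weaker inhibitor, a lower number a stronger inhibitor), compound 1 gives 14000 nM. Compound 2 `CNC(=O)/C(C)=C/c1ccc(NC(=O)Nc2ccc(Cl)c(C(F)(F)F)c2)cc1` has a 2-(methylcarbamoyl)prop-1-en-1-yl group in its place. In this assay compound 2 reaches only a limit of the assay, > 50000 nM. Compound 3 `O=C(CCc1ccc(NC(=O)Nc2ccc(Cl)c(C(F)(F)F)c2)cc1)NC1CCC1` bears a 2-(cyclobutylcarbamoyl)ethyl group, and in this assay compound 3 gives 21300 nM, the higher of the two actual numbers, though its gap to compound 1 is within the scatter (a 1.5-fold higher number from compound 1 to compound 3 (0.18 log units; within the scatter)). Compound 4 `O=C(/C=C/c1ccc(NC(=O)Nc2ccc(Cl)c(C(F)(F)F)c2)cc1)NC1CCC1` differs from compound 3 in one place: 2-(cyclobutylcarbamoyl)ethenyl in place of 2-(cyclobutylcarbamoyl)ethyl on an aromatic carbon. Within the data shown here, two measured steps bear on this: an at least 3.5-fold higher number from compound 1 to compound 2 (0.55 log units; beyond the scatter) and an at least 2.3-fold lower number from compound 2 to compound 3 (0.37 log units; beyond the scatter). Both rest on compound 2, whose value is only a limit, (the limit of > 50000 nM in this assay, at which 1 of the 3 values shown sits). In both, the form with a double bond outside the aromatic rings gave the higher number, yet compound 2 also carries an extra methyl, so the expected step is a modest rise, a 1.5-fold higher number from compound 3 to compound 4 (0.18 log units; within the scatter). Compound 4 is therefore estimated at 32000 nM, with a range from 11000 nM to 90000 nM.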

Compound 4, half-maximal inhibitory concentration: 4430 nM
The estimate for compound 4 lay 7.2-fold (0.86 log units) above the measured number, and the stated range ends above it.
By their numbers in this assay, from the lowest: compound 4; then compounds 1 and 3 (each within the scatter of the next). At a limit, above all of these: compound 2.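

Swapping 2-(cyclobutylcarbamoyl)ethyl for 2-(cyclobutylcarbamoyl)ethenyl on this aromatic carbon, para to a large group, adds one double bond outside the aromatic rings and gives a 4.8-fold lower number from compound 3 to compound 4 (0.68 log units; beyond the scatter) in this assay. A double bond in this chain therefore need not go with a higher number, as the comparison with compound 2 had hinted, and a 3.2-fold lower number from compound 1 to compound 4 (0.50 log units; beyond the scatter) leaves compound 4 with the lowest number of the four. The step of an at least 11-fold lower number from compound 2 to compound 4 (1.05 log units; beyond the scatter) gives only a bound, as compound 2 stands at a limit: the limit of > 50000 nM in this assay, at which 1 of the 4 values shown sits.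

As far as these compounds go, the methyl amide and the cyclobutyl amide appear here only on different chains, so what the cyclobutyl ring itself contributes stays open. Also open, from the compounds shown here alone, is whether the double bond has the same effect when a carboxylic acid or an amine ends the chain.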